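The source may report more compounds than this note shows. Statements on the series, on what has been measured and on what is new or still open speak of the compounds shown alone.

Measured in an ADME assay on the whole organism (Rattus norvegicus) for metabolic stability, using cassette dosing; a lower number here means that the compound disappears faster, a higher number that the compound lasts longer:
- compound 1 `Nc1cc(Oc2ccc(NC(=O)Nc3cccc(C(F)(F)F)c3)cc2)ncn1` gives 3.2 h 
- compound 2 `CNc1cc(Oc2ccc(NC(=O)Nc3cccc(C(F)(F)F)c3)cc2)ncn1` gives 3.2 h 

Against compound 1, compound 2 stands level at 3.2 h on the numbers so far. The next analogue is compound 3 `CC(C)(O)CNc1cc(Oc2ccc(NC(=O)Nc3cccc(C(F)(F)F)c3)cc2)ncn1`, which carries 1-hydroxy-1-methylethyl in place of hydrogen on a saturated chain carbon bound to a nitrogen on an aromatic ring. The difference is 1-hydroxy-1-methylethyl in place of hydrogen on a saturated chain carbon bound to a nitrogen on an aromatic ring and, cut one bond further out, reads methyl to 2-hydroxy-2-methylpropyl.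

For the measured compounds named here, only one measured step bears on this change. The step of no change at the digits printed from compound 1 to compound 2 (within the scatter) lies within the scatter and put methyl in place of hydrogen on a nitrogen on an aromatic ring. Going by the values given here, it shows tolerance for that smaller change only, and no measured compound carries 1-hydroxy-1-methylethyl, so the evidence is thin and the range is kept wide. Going by these compounds, no step beyond the scatter is expected in this assay, and the direction remains open, with a slight drop as the central guess. The estimated step is a 1.1-fold lower number from compound 2 to compound 3 (0.06 log units; within the scatter) and remains an expectation. For compound 3 the expected half-life is 2.8 h, with an estimated range from 1.3 h to 5.5 h.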

Compound 3, half-life: 3.7 h
Compound 3: the middle estimate sits 1.3-fold (0.12 log units) below what was measured, within the range that was stated.
By their numbers in this assay, from the lowest: compounds 1, 2 and 3 (each within the scatter of the next).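

In this assay the nitrogen on the aromatic ring tolerates much more than a methyl: 2-hydroxy-2-methylpropyl in place of hydrogen there gives (a 1.2-fold higher number from compound 1 to compound 3 (0.06 log units; within the scatter)), and 1-hydroxy-1-methylethyl on the saturated chain carbon bound to that nitrogen gives (a 1.2-fold higher number from compound 2 to compound 3 (0.06 log units; within the scatter)). Neither step leaves the scatter, so hydrogen, methyl and 2-hydroxy-2-methylpropyl on this nitrogen all read alike, and the level half-life now extends to a branched substituent carrying a hydrogen-bond donor and acceptor, which the methyl of compound 2 could not show. Nothing measured on these compounds explains why the half-life stays level through this change.

Still open, going by these compounds, is whether the same holds when the hydroxyl of the 2-hydroxy-2-methylpropyl group gives way to an amine or a carboxylic acid, or when a longer chain stands on this nitrogen. The three compounds also share everything else, including the trifluoromethyl group and the urea, so they say nothing about how changes elsewhere on the shared core would read in this assay.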